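The source may report more compounds than this note shows. Statements on the series, on what has been measured and on what is new or still open speak of the compounds shown alone.

In an ADME assay on T29 cells (Homo sapiens) for cytotoxicity, read by sulforhodamine B assay, with a stated time of 3 days (on this read-out lower numbers stand for stronger inhibition and higher numbers for weaker inhibition), compound 1 (`O=Cc1cn(Cc2ccc(Cl)cc2)c2ccc(Cl)cc12`) reads > 31600 nM and this is a limit of the assay, not a number. Compound 2 (`OCc1cn(Cc2ccc(Cl)cc2)c2ccccc12`) reads > 31600 nM and this too is a limit. For the measured compounds named here, compound 3 (`OCc1cn(Cc2ccc(Cl)cc2)c2ccc(F)cc12`) gives 8120 nM as the only true number among the three, so there is no other measured number to rank it against.

Compound 4 (`OCc1cn(Cc2ccc(Cl)cc2)c2ccc(Cl)cc12`) changes one group of compound 3, with chloro in place of fluoro on an aromatic carbon. Going by the values given here, one measured step bears on this carbon: an at least 3.8-fold lower number from compound 2 to compound 3 (0.59 log units; beyond the scatter) when fluoro replaces hydrogen there. From the compounds shown here alone, that step shows that the group on this carbon can matter, but one end of it is a limit, so its true size is unknown. It also says nothing directly about chloro. Compound 1 carries chloro on this carbon too, but it differs elsewhere, so it gives no size for this swap.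

Among the compounds with values here, with no measured step from fluoro to chloro, compound 4 is expected to stay near compound 3, in no firm direction. The expected result is a 1.2-fold lower number from compound 3 to compound 4 (0.06 log units; within the scatter) and this estimated step stays inside the usual scatter. The estimate for compound 4 is 7000 nM with an expected range from 2500 nM to 25000 nM in this measurement.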

Compound 4, half-maximal inhibitory concentration: > 31600 nM
Compound 4 ended at the assay's limit; the forecaster's own chance of this, stated with the estimate: 15%; middle value at least 4.5-fold (0.65 log units) away from the limit.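

Fluoro and chloro are not interchangeable on this aromatic carbon in this assay: the swap gives an at least 3.8-fold higher number from compound 3 to compound 4 (0.59 log units; beyond the scatter), so the lower number that fluoro brought over hydrogen does not carry over to chloro. With hydroxymethyl held in place, only fluoro on this carbon gives a true number, while hydrogen in compound 2 and chloro in compound 4 both leave the read-out at a limit, so the series shows no steady trend from hydrogen through fluoro to chloro. The steps to compound 4 from compound 2 and from compound 1 cannot be read, and the true size of the step from fluoro to chloro stays unknown too, because one or both ends of each step sit at the same ceiling: the limit of > 31600 nM in this assay, at which 3 of the 4 values shown sit.

From the compounds shown here alone, whether fluoro is a special case on this carbon stays open, and a methyl, a methoxy or a nitrile there would help to test it. Also open, going by these compounds, is how much the hydroxymethyl itself contributes when fluoro is kept, which a formyl, an amine or a carboxylic acid in its place could show.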